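The compounds below may be only part of what the source reports. "The series", "measured", "known", "first", "only" and "open" are said of these compounds alone.

Working notes on the series. Compound 2 `O=C(Nc1cccc(-n2cc(-c3ccncc3)c(-c3cc(O)cc(Cl)c3)n2)c1)Nc1ccc(Cl)c(Cl)c1` is the reference point here. In a functional assay on OVCAR-4 cells (Homo sapiens) for inhibition, read by sulforhodamine B assay, with a stated time of 48 h, tested at 0.1 uM (on this read-out lower numbers stand for a stronger effect and higher numbers for a weaker effect at the one concentration tested), compound 2 gives 95%, and in the same read-out compound 1 `O=C(Nc1cccc(-n2cc(-c3ccncc3)c(-c3cc(O)cc(Cl)c3)n2)c1)Nc1ccc(Cl)c(C(F)(F)F)c1` gives 105% while compound 3 `COc1cc(Cl)cc(-c2nn(-c3cccc(NC(=O)Nc4cc(C(F)(F)F)cc(C(F)(F)F)c4)c3)cc2-c2ccncc2)c1` gives 97%; all three numbers lie within the usual scatter of one another, so no order among them can be read. For the measured compounds named here, the only single-point step among the measured compounds is a number 10 percentage points lower from compound 1 to compound 2 (within the scatter), and it concerns the urea end of the molecule, not the site now in question.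

The change from compound 2 to compound 4 `COc1cc(Cl)cc(-c2nn(-c3cccc(NC(=O)Nc4ccc(Cl)c(Cl)c4)c3)cc2-c2ccncc2)c1` is methyl in place of hydrogen on an oxygen on an aromatic ring. Going by the values given here, no measured pair isolates this change: compound 3 carries the methoxy, but it differs from compound 1 in more than one place, so its number and that of compound 1 can only be noted side by side, and they too sit within the scatter. With nothing in hand that moves this read-out beyond the scatter, compound 4 is expected to stay close to compound 2, at an estimated 97% with a range of 85% to 109%. That estimate corresponds to a number 2 percentage points higher from compound 2 to compound 4 (within the scatter), expected to fall within the scatter.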

Compound 4, a percentage reported as activity, at one concentration (the size of the read-out at that concentration, not a potency): 95%
Beside the measured number, compound 4's estimate is 2 percentage points above it; low and high end bracket the measured number.
By their numbers in this assay, from the lowest: compounds 2, 4, 3 and 1 (each within the scatter of the next).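

The hydroxy to methoxy swap on the 3-chloro-5-hydroxyphenyl group now stands as an isolated pair, with no change at the digits printed from compound 2 to compound 4 (within the scatter) in this assay. The earlier compounds shown here offered only a side-by-side reading of the methoxy; this pair shows that, with the dichlorophenyl urea end held constant, methyl in place of hydrogen on this oxygen leaves the read-out at one concentration within the scatter, though that single concentration says nothing about potency. No supporting data bear on why the swap has so little effect on this read-out.

Still open, from the compounds shown here alone, is whether a longer chain on this oxygen, or an amine or a carboxylic acid at this position, would move the read-out beyond the scatter. Compound 1 and compound 3 differ in more than one place, so the same swap remains unresolved for urea ends carrying trifluoromethyl.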